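The compounds below may be only part of what the source reports. "The series", "measured", "known", "first", "only" and "open" are said of these compounds alone.

Compound 1 `Cn1c(Cc2nn(C)c(=O)c3ccccc23)nnc1SCC(=O)Nc1ccc(Cl)cc1Cl` gives 21100 nM in an assay on 32D cells for inhibition of interleukin-15 (Mus musculus), read by resazurin assay, with stated times of 30 min and 2.5 days, in the presence of a further agent that is not named here; a higher number here means a weaker inhibitor, a lower number a stronger inhibitor. Compound 2 `Cn1nc(Cc2nnc(SCC(=O)Nc3ccc(Cl)cc3Cl)n2CCCO)c2ccccc2c1=O` returns only the limit > 30000 nM in this assay, a boundary of the measurement rather than a number.

Compound 1 thus stands on the only number shown, its single neighbour sitting at a limit (the limit of > 30000 nM in this assay, at which 1 of the 2 values shown sits). Compound 3 `Cn1c(Cc2nn(CCCO)c(=O)c3ccccc23)nnc1SCC(=O)Nc1ccc(Cl)cc1Cl` differs from compound 1 by 2-hydroxyethyl in place of hydrogen on a saturated chain carbon bound to an aromatic nitrogen. Within the data shown here, the one measured step, an at least 1.4-fold higher number from compound 1 to compound 2 (0.15 log units; that floor lies within the scatter), made the same kind of addition on a different aromatic nitrogen and did not clearly move the number beyond the scatter. A step of similar size is therefore expected for compound 3, a 1.4-fold higher number from compound 1 to compound 3 (0.15 log units; within the scatter), toward a weaker result or none. Compound 3 is estimated at 30000 nM, with a range from 15000 nM to 60000 nM.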

Compound 3, half-maximal inhibitory concentration: > 30000 nM
Compound 3: a limit, no number (the forecaster's own chance of this, stated with the estimate: 50%); the middle value lies on the limit itself.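

In this assay, replacing methyl with 3-hydroxypropyl at this second aromatic nitrogen gives an at least 1.4-fold higher number from compound 1 to compound 3 (0.15 log units; that floor lies within the scatter). Compound 3 reaches only a limit, so this step sets a floor and gives no size, and that floor does not clear the usual scatter. The same addition at two different aromatic nitrogens now ends at the same limit: the limit of > 30000 nM in this assay, at which 2 of the 3 values shown sit.

As far as these compounds go, how far compound 3 truly lies from compound 1 remains open. Also open, from the compounds shown here alone, is whether a plain propyl chain, or an amine or carboxylic acid at the chain end, would give a measurable number here.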